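Fluoro for methyl on the aryl imine of compound 4

A few compounds are considered here, and "the series" means these few. Any claim that something is new, unique, unknown or untested is made for them only; others in the source may bear on it.

Compound 3 `Cc1ccc(/N=C2/NC(=O)/C(=C/c3ccccn3)S2)cc1` gives the highest of the three numbers in a functional assay on the whole organism (strain Wistar) for inhibition, with Rattus norvegicus as the target, read by paw edema, with stated times of 30 min and 120 min, at a dose of 10 mg/kg by the oral route (a lower number here means less inhibition, a higher number more inhibition at the dose given (going by the name of the read-out)), at 43.8%. Its nearest neighbour is compound 2 `Cc1cccc(/N=C2/NC(=O)/C(=C/c3ccccn3)S2)c1`, which gives 39.7%, and the gap a number 4.1 percentage points higher from compound 2 to compound 3 (within the scatter) lies within the scatter, so the two cannot be ordered. Among the measured compounds shown here, compound 1 `O=C1N/C(=N/c2ccccc2)S/C1=C\c1ccccn1`, the unsubstituted parent, gives 26.2%, and the rises a number 13.5 percentage points higher from compound 1 to compound 2 (beyond the scatter) and a number 17.6 percentage points higher from compound 1 to compound 3 (beyond the scatter) are the only steps beyond the scatter in this set; both come from methyl in place of hydrogen on an aromatic carbon.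

Compound 4 `O=C1N/C(=N/c2ccc(F)cc2)S/C1=C\c1ccccn1` differs from compound 3 by fluoro in place of methyl on an aromatic carbon. For the measured compounds named here, no measured step tells how fluoro compares with methyl at this place; the measured steps only show that a methyl group gave a modest gain over hydrogen. The expectation is therefore a step of a number 5.8 percentage points lower from compound 3 to compound 4 (within the scatter) that stays within the scatter. Compound 4 is estimated at 38%, within a range from 26% to 50%.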

Compound 4, a percentage reported as inhibition, in the whole organism at one dose (the size of the read-out at that dose, not a potency): 34.7%
For compound 4 the middle estimate is 3.3 percentage points above the measured one; the range from low to high includes it.
By their numbers in this assay, from the lowest: compounds 1, 4, 2 and 3 (each within the scatter of the next, the first and the last beyond it).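

Fluoro at this place, on an aromatic carbon para to a large group, gives a number 9.1 percentage points lower from compound 3 to compound 4 (within the scatter) in this assay, and the change from 3-methylphenyl to 4-fluorophenyl gives a number 5 percentage points lower from compound 2 to compound 4 (within the scatter), so compound 4 cannot be ordered against either methyl compound. Fluoro in place of hydrogen gives a number 8.5 percentage points higher from compound 1 to compound 4 (within the scatter), so unlike the two methyl steps from compound 1, this step does not separate compound 4 from the unsubstituted parent. Compound 4 therefore cannot be ordered against any of the three earlier compounds, and no evidence on why is available here. As far as these compounds go, it remains open whether chloro, methoxy or an amine at this place would stand clear of compound 1. Also open, from the compounds shown here alone, is how fluoro would read at the place the methyl holds in compound 2.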